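Cytotoxicity notes: chloro to benzylcarbamoylmethoxy on the core

The source may report more compounds than this note shows. Statements on the series, on what has been measured and on what is new or still open speak of the compounds shown alone.

Compound 1 `COc1ccc(-c2cc(-c3ccc4c(c3)CCCC4)[nH]c(=S)c2C#N)cc1OC` gives 29400 nM in an ADME assay on RAW264.7 cells (Mus musculus) for cytotoxicity, with a stated time of 24 h; on this read-out higher numbers stand for weaker inhibition and lower numbers for stronger inhibition. For compound 2 `N#Cc1c(-c2c[nH]c3ccccc23)cc(-c2ccc3c(c2)CCCC3)[nH]c1=S` this assay reports only a limit, > 100000 nM. For compound 3 `COc1ccc(-c2cc(-c3ccc4c(c3)CCCC4)nc(Cl)c2C#N)cc1OC` this assay likewise reports only a limit, > 50000 nM. Of the three values shown, one sits at the limit of > 100000 nM in this assay, at which 1 of the 3 values shown sits, and one at the limit of > 50000 nM in this assay, at which 1 of the 3 values shown sits, so compound 3 stands among the limits rather than at a measured number. Compound 4 `COc1ccc(-c2cc(-c3ccc4c(c3)CCCC4)nc(OCC(=O)NCc3ccccc3)c2C#N)cc1OC` differs from compound 3 in one place: (benzylcarbamoyl)methoxy in place of chloro on an aromatic carbon. No step between measured compounds is shown for this kind of change. Compound 4 is expected to remain weakly cytotoxic, with the step that the limit leaves unreadable from compound 3 to compound 4 expected to lie within the scatter, in no firm direction. The estimate for compound 4 in this assay is 60000 nM, within 25000 nM to 150000 nM.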

Compound 4, half-maximal inhibitory concentration: 8400 nM
Compound 4: the middle estimate sits 7.1-fold (0.85 log units) above what was measured; the whole stated range lies above it.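

In this assay, (benzylcarbamoyl)methoxy in place of chloro, next to the ring nitrogen and ortho to a cyano group, gives an at least 5.9-fold lower number from compound 3 to compound 4 (0.77 log units; beyond the scatter), so the group at this position does bear on cytotoxicity. From the compounds shown here alone, compound 3 is only a limit, > 50000 nM, so the true size of the step stays unknown. No measured property at hand accounts for the step.

Still open, going by these compounds, is which part of the new group carries the step: the benzyl ring, the amide or the ether oxygen. A plain methoxy, an amine or a carboxylic acid at this position would help separate these parts.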